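Series notes: furan-2-yl for nitro, cytotoxicity outlook

A few compounds are considered here, and "the series" means these few. Any claim that something is new, unique, unknown or untested is made for them only; others in the source may bear on it.

Measured compounds:
Compound 1 `O=C(Nc1cccc(N2CCCC2=O)c1)C1CCCN(C(=O)c2cc(C(F)(F)F)cc(C(F)(F)F)c2)C1` in an ADME assay on PC-3 cells (Homo sapiens) for cytotoxicity, read by WST assay, tested at 100 uM; on this read-out higher numbers stand for more inhibition at the one concentration tested (going by the name of the read-out) and lower numbers for less inhibition: 0%
Compound 2 `O=C(Nc1ccc(Cl)cc1)C1CCCN(C(=O)c2cccc([N+](=O)[O-])c2)C1` in this assay: 0%
Compound 3 `O=C(Nc1cccc(-c2cnco2)c1)C1CCCN(C(=O)c2cc(C(F)(F)F)cc(C(F)(F)F)c2)C1` in this assay: 9%

Compound 2 stands level with compound 1 at the digits shown; together they are the lowest of the three numbers. Compound 3 lies a few points higher, but that gap is within the usual scatter, so no order among the three can be read from these values.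

The unmeasured compound is compound 4 `O=C(Nc1ccc(Cl)cc1)C1CCCN(C(=O)c2cccc(-c3ccco3)c2)C1`. Its difference from compound 2 is furan-2-yl in place of nitro on an aromatic carbon.

For the measured compounds named here, only one measured step exists, a number 9 percentage points higher from compound 1 to compound 3 (within the scatter), and it is within the scatter. It changes a group on the other aromatic ring of the shared core, not the ring where the furan-2-yl enters, so it speaks only indirectly to the present step. It does show that an aromatic five-membered heteroaryl ring entering on an aromatic carbon left cytotoxicity essentially unchanged. Going by the values given here, every value in this assay so far sits at or near the floor, and nothing among the measured compounds points to a step beyond the scatter here.

Compound 4 is therefore expected to show a number 3 percentage points higher from compound 2 to compound 4 (within the scatter), a change not beyond the scatter. The estimate for compound 4 is 3%, with a range from 0% to 15%.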

Compound 4, a percentage reported as inhibition, at one concentration (the size of the read-out at that concentration, not a potency): 0%
Beside the measured number, compound 4's estimate is 3 percentage points above it; low and high end bracket the measured number.
By their numbers in this assay, from the lowest: compounds 1, 2, 4 and 3 (each within the scatter of the next).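

The step of furan-2-yl in place of nitro, on an aromatic carbon of a six-membered aromatic ring of carbon only and meta to a large group, reads no change at the digits printed from compound 2 to compound 4 (within the scatter) in this assay. For the compounds shown here, this is the first direct reading at this position, as the only earlier step changed a group on the other aromatic ring of the shared core. With compound 2 at 0%, the step could only have shown a rise, so it shows that furan-2-yl adds no inhibition beyond the scatter at the one concentration tested, but not that the two groups are alike in any other respect, and no measurement at hand accounts for this outcome.

As far as these compounds go, whether an amine or a carboxylic acid in place of nitro at this position would give a number beyond the scatter in this assay remains open. Also open, from the compounds shown here alone, is whether furan-2-yl would read the same alongside the other groups carried by compound 1 and compound 3, as this single step comes from one background only.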